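A few compounds are considered here, and "the series" means these few. Any claim that something is new, unique, unknown or untested is made for them only; others in the source may bear on it.

For the measured compounds named here, in a functional assay on HepG2 cells (Homo sapiens) for antiproliferative activity, read by CCK-8 assay, with a stated time of 48 h (a higher number here means a weaker inhibitor, a lower number a stronger inhibitor), compound 2 `COc1ccc(/C=C\c2cc(OC)c(OC)c(OC)c2)cc1OCc1ccc(CNCCN(C)C)cc1` gives 4400 nM, the only actual number so far. Compound 1 `COc1ccc(/C=C\c2cc(OC)c(OC)c(OC)c2)cc1OCc1ccc(CN2CCCC[C@H]2C(=O)O)cc1` reads > 10000 nM, which is a limit of the assay and not a number. Going by the values given here, the one measured step is an at least 2.2-fold lower number from compound 1 to compound 2 (0.35 log units; beyond the scatter), and it puts (2-(dimethylamino)ethyl)amino in place of 2-carboxypiperidin-1-yl. Compound 3 `COc1ccc(/C=C\c2cc(OC)c(OC)c(OC)c2)cc1OCc1ccc(CN2CC[C@@H](C(=O)O)C2)cc1` moves back towards compound 1: 3-carboxypyrrolidin-1-yl in place of (2-(dimethylamino)ethyl)amino on a saturated chain carbon bound to an aromatic carbon. Here 3-carboxypyrrolidin-1-yl replaces (2-(dimethylamino)ethyl)amino on a saturated chain carbon bound to an aromatic carbon, so a carboxy-substituted non-aromatic ring returns, though with one five-membered ring. Going by compound 1 and its step of an at least 2.2-fold lower number from compound 1 to compound 2 (0.35 log units; beyond the scatter), read in reverse, a change to a higher number of similar size is expected in this assay, and the reading may again be only a limit. The estimated step is a 2.5-fold higher number from compound 2 to compound 3 (0.40 log units; beyond the scatter). Compound 3 is expected at about 11000 nM, with an estimated range of 4500 nM to 30000 nM.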

Compound 3, half-maximal inhibitory concentration: 2300 nM
Compound 3: middle estimate off by 4.8-fold (0.68 log units), on the high side; the measured number lies below the stated range.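

In this assay, 3-carboxypyrrolidin-1-yl in place of (2-(dimethylamino)ethyl)amino, on a saturated chain carbon bound to an aromatic carbon, gives a 1.9-fold lower number from compound 2 to compound 3 (0.28 log units; within the scatter), so the two groups cannot be told apart here. A carboxy group on a non-aromatic ring therefore does not by itself go with the weak reading of compound 1, as 3-carboxypyrrolidin-1-yl in place of 2-carboxypiperidin-1-yl gives an at least 4.3-fold lower number from compound 1 to compound 3 (0.63 log units; beyond the scatter). The reading of compound 1 is a limit of the assay and not a number, so this step is only a bound: the limit of > 10000 nM in this assay, at which 1 of the 3 values shown sits.

Ring size and the place of the carboxy group differ together from compound 1 to compound 3, so these compounds cannot separate the two. A 3-carboxypiperidin-1-yl group would separate them, and a plain pyrrolidin-1-yl group would show what the carboxylic acid adds.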